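Swapping 4-methoxyphenyl for 3-fluorophenyl on a sulfur

The compounds below may be only part of what the source reports. "The series", "measured", "known", "first", "only" and "open" are said of these compounds alone.

Compound 1 `COc1ccc(SCc2ccc(/C=C/C(=O)Nc3ccccc3N)cc2)cc1OC`: 46.4%
Compound 2 `Nc1ccccc1NC(=O)/C=C/c1ccc(CSc2cccc(F)c2)cc1`: 9.08%
Compound 3 `COc1ccc(SCc2ccc(C(=O)Nc3ccccc3N)cc2)cc1`: 81.8%

All three compounds were tested in a functional assay on A-375 cells (Homo sapiens) for inhibition, read by CCK-8 assay, with a stated time of 72 h, tested at 8 uM (on this read-out lower numbers stand for less inhibition of growth and higher numbers for more inhibition of growth at the one concentration tested), and compound 3 gives the highest number of the set, well clear of compound 1 and further still from compound 2. The next compound to be tested is compound 4 `Nc1ccccc1NC(=O)c1ccc(CSc2cccc(F)c2)cc1`, which keeps the core of compound 3 and differs in one place: 3-fluorophenyl in place of 4-methoxyphenyl on a sulfur.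

Going by the values given here, only one measured step bears on this change. It also brings in 3-fluorophenyl on a sulfur, replacing 3,4-dimethoxyphenyl on the core of compound 1, and it gives a number 37.3 percentage points lower from compound 1 to compound 2 (beyond the scatter). That is a large fall, beyond the scatter. The group that leaves there is a different one and the core is also different, so this single pair is only a rough guide. A fall of similar size is still the best expectation in this assay, with real doubt about its exact extent. The estimated step is a number 33.8 percentage points lower from compound 3 to compound 4 (beyond the scatter), a drop beyond the scatter. For compound 4 the expected value is 48%, with an estimated range from 20% to 76%.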

Compound 4, percent growth inhibition at one concentration: 76.3%
Estimate against measurement, compound 4: 28.3 percentage points below; measured number outside the range, above it.
By their numbers in this assay, from the lowest: compound 2; then compound 1; then compounds 4 and 3 (each within the scatter of the next).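

On the core of compound 3, in this assay the swap of 4-methoxyphenyl for 3-fluorophenyl on a sulfur gives a number 5.5 percentage points lower from compound 3 to compound 4 (within the scatter) and so leaves the two compounds indistinguishable, which shows that this position can accept either ring on this core without a measurable loss of growth inhibition at the one concentration tested. The step that pointed to a large fall, a number 37.3 percentage points lower from compound 1 to compound 2 (beyond the scatter) on the core of compound 1, therefore does not carry over to this core, although that step also removes a different group, so the core and the departing group cannot be separated as the source of the contrast. No measurement here accounts for the difference between the two steps.

The compounds shown leave open whether the core or the departing group matters more, since neither 3,4-dimethoxyphenyl on the core of compound 3 nor 4-methoxyphenyl on the core of compound 1 appears among them. They also leave open whether this tolerance extends beyond these aromatic rings, for example to a phenyl ring carrying an amine or a carboxylic acid on the sulfur.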